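Sulfonylurea series: methyl removal from compound 3

The source may hold more compounds than are shown below. What is called first, only, known or untested is meant among the compounds shown, and "the series" means these compounds.

Measured compounds in a functional assay on the whole organism (Mus musculus) for inhibition, at a dose of 150 mg/kg by the oral route; a lower number here means less inhibition, a higher number more inhibition at the dose given (going by the name of the read-out):
compound 1 `O=C(Nc1ccc(Cl)cc1)NS(=O)(=O)c1csc2ccccc12` gives 43%
compound 2 `O=C(Nc1ccc(Cl)cc1)NS(=O)(=O)c1cc2ccccc2[nH]1` gives 26%
compound 3 `Cc1ccc2sc(S(=O)(=O)NC(=O)Nc3ccc(Cl)cc3)cc2c1` gives 10%

Compound 3 stands lowest of the three numbers; its nearest neighbour is compound 2, and compound 1 lies furthest above it, both gaps beyond the scatter. Compound 4 `O=C(Nc1ccc(Cl)cc1)NS(=O)(=O)c1cc2ccccc2s1` differs from compound 3 by hydrogen in place of methyl on an aromatic carbon. Among the measured compounds shown here, no step between two measured compounds isolates this change, so its size is not known from the series. With compound 3 at 10%, the step is expected to be small, likely toward higher inhibition in this assay but possibly within the scatter: a number 8 percentage points higher from compound 3 to compound 4 (within the scatter). Compound 4 is estimated at 18%, between 5% and 35%.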

Compound 4, a percentage reported as inhibition, in the whole organism at one dose (the size of the read-out at that dose, not a potency): 47%
Compound 4: the middle estimate sits 29 percentage points below what was measured, outside the stated range (above it).
By their numbers in this assay, from the lowest: compound 3; then compound 2; then compounds 1 and 4 (each within the scatter of the next).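

In this assay hydrogen in place of methyl on an aromatic carbon gives a number 37 percentage points higher from compound 3 to compound 4 (beyond the scatter), so a single added carbon at this position of the six-membered aromatic ring is enough to change the read-out well beyond the scatter. The low number of compound 3 therefore goes with the methyl and not with the core it shares with compound 4. Nothing at hand bears on the reason for this step.

On these data alone, whether the drop is specific to methyl remains open. A fluorine, a methoxy group or an ethyl chain at this position could land near either compound 3 or compound 4.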